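A few compounds are considered here, and "the series" means these few. Any claim that something is new, unique, unknown or untested is made for them only; others in the source may bear on it.

Measured compounds: compound 1 `CC(c1ccc(-c2ccccc2)c(F)c1)c1nnc2n1N=C(c1ccc(C(F)(F)F)cc1)CS2`, 4300 nM; compound 2 `CC(C)Cc1ccc(C(C)c2nnc3n2N=C(c2ccc([N+](=O)[O-])cc2)CS3)cc1`, "not active" (no number reported); compound 3 `CC(c1ccc(-c2ccccc2)c(F)c1)c1nnc2n1N=C(c1ccc([N+](=O)[O-])cc1)CS2`, 7800 nM.

Three compounds were tested in a functional assay on MCF7 cells (Homo sapiens) for inhibition, read by sulforhodamine B assay, with a stated time of 72 h; a lower number here means a stronger inhibitor, a higher number a weaker inhibitor. Compound 1 gives 4300 nM and compound 3 gives 7800 nM in this assay, while compound 2 is reported as "not active" (no number reported). Compound 1 differs from compound 3 by trifluoromethyl in place of nitro on an aromatic carbon, a step that reads a 1.8-fold lower number from compound 3 to compound 1 (0.26 log units; within the scatter). The cores of compound 2 and compound 3 differ in more than one place; that difference is not broken down here. Compound 4 `CC(C)Cc1ccc(C(C)c2nnc3n2N=C(c2ccc(C(F)(F)F)cc2)CS3)cc1` has not yet been measured; it differs from compound 2 by trifluoromethyl in place of nitro on an aromatic carbon, the same change at the same place as between compound 3 and compound 1. The expectation rests on compound 2 being reported as "not active" (no number reported) and on the earlier step of a 1.8-fold lower number from compound 3 to compound 1 (0.26 log units; within the scatter), which stayed within scatter. Compound 4 is therefore expected to remain a weak inhibitor, estimated near 25000 nM, between 6000 nM and 100000 nM, with a real chance that no number is reported again.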

Compound 4, half-maximal inhibitory concentration: 4200 nM
Compound 4: middle estimate off by 6.0-fold (0.77 log units), on the high side; measured number outside the range, below it.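

Going by these compounds alone, compound 2 carries no number in this assay, so no step from compound 2 to compound 4 can be read. No evidence on hand bears on this result. The compounds shown leave open how far compound 2 truly lies from compound 4.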